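Swapping the Aryl Urea Cap from Compound 3 to Compound 4

The compounds below may be only part of what the source reports. "The series", "measured", "known", "first", "only" and "open" are said of these compounds alone.

Compound 3 `Cc1ccccc1NC(=O)Nc1cccc(CNc2nccnc2Cl)c1` gives 13600 nM in a functional assay on T-24 cells (Homo sapiens) for antiproliferative activity, read by MTT assay, with a stated time of 48 h (a higher number here means a weaker inhibitor, a lower number a stronger inhibitor), the lowest of the two numbers shown; compound 1 `O=C(Nc1ccccc1)Nc1cccc(CNc2nccnc2Cl)c1` gives 19800 nM, and a 1.5-fold lower number from compound 1 to compound 3 (0.16 log units; within the scatter). Compound 2 `O=C(Nc1cccc(CNc2nccnc2Cl)c1)NC1CCCCC1` reaches only a limit of this assay, > 40000 nM (the limit of > 40000 nM in this assay, at which 1 of the 3 values shown sits). The steps of an at least 2.0-fold higher number from compound 1 to compound 2 (0.30 log units; that floor lies within the scatter) and an at least 2.9-fold lower number from compound 2 to compound 3 (0.46 log units; beyond the scatter) point the same way, favouring an aryl cap over cyclohexyl. Compound 4 `CN(C)c1ccc(NC(=O)Nc2cccc(CNc3nccnc3Cl)c2)cc1` differs from compound 3 by 4-(dimethylamino)phenyl in place of 2-methylphenyl on an amide-type nitrogen. Within the data shown here, the two measured aryl caps sit within the scatter of each other, and no measured step covers a 4-(dimethylamino)phenyl, so no step beyond the scatter is expected, a 1.1-fold higher number from compound 3 to compound 4 (0.04 log units; within the scatter). Compound 4 is therefore estimated at 15000 nM, between 6000 nM and 40000 nM.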

Compound 4, half-maximal inhibitory concentration: 20200 nM
The estimate for compound 4 lay 1.3-fold (0.13 log units) below the measured number; the measured number falls inside the stated range.
By their numbers in this assay, from the lowest: compounds 3, 1 and 4 (each within the scatter of the next). At a limit, above all of these: compound 2.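

The 4-(dimethylamino)phenyl cap shows that a nitrogen-bearing substituent on the aryl ring at this amide-type nitrogen moves the number by no more than the scatter, with a 1.5-fold higher number from compound 3 to compound 4 (0.17 log units; within the scatter) and a 1.0-fold higher number from compound 1 to compound 4 (0.01 log units; within the scatter) as the two steps. Unlike the step from compound 2 to compound 3, an at least 1.9-fold lower number from compound 2 to compound 4 (0.29 log units; that floor lies within the scatter) gives no firm separation from the cyclohexyl cap. Compound 2 remains only a limit: the limit of > 40000 nM in this assay, at which 1 of the 4 values shown sits.

The compounds shown leave open whether a carboxylic acid or a primary amine on the phenyl cap would shift the number beyond the scatter.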